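From Amino to Methanesulfonamido: Compound 2 to Compound 4

A few compounds are considered here, and "the series" means these few. Any claim that something is new, unique, unknown or untested is made for them only; others in the source may bear on it.

Of the compounds shown here, three on a shared core have been measured in an assay on cells for inhibition of ileal sodium/bile acid cotransporter (Homo sapiens); on this read-out lower numbers stand for stronger inhibition and higher numbers for weaker inhibition. Compound 1 `CCCC[C@]1(CC)CS(=O)(=O)c2ccc(OC)cc2[C@@H](c2ccccc2)[C@H]1O` gives 55 nM, compound 2 `CCCC[C@]1(CC)CS(=O)(=O)c2ccc(N)cc2[C@@H](c2ccccc2)[C@H]1O` gives 68 nM, and compound 3 `CCCC[C@]1(CC)CS(=O)(=O)c2ccc(NC(C)=O)cc2[C@@H](c2ccccc2)[C@H]1O` gives 90 nM. Compound 2 sits between the other two on these numbers, yet both gaps are small: a 1.2-fold higher number from compound 1 to compound 2 (0.09 log units; within the scatter) and a 1.3-fold higher number from compound 2 to compound 3 (0.12 log units; within the scatter), so no ranking among the three can be drawn from this assay.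

Compound 4 `CCCC[C@]1(CC)CS(=O)(=O)c2ccc(NS(C)(=O)=O)cc2[C@@H](c2ccccc2)[C@H]1O` takes the step (methylsulfonyl in place of hydrogen on a nitrogen on an aromatic ring). The measured step that bears most directly on it is the one in which the same nitrogen carried an acetyl group instead, a 1.3-fold higher number from compound 2 to compound 3 (0.12 log units; within the scatter), which stayed within the scatter. The related exchanges at the same aromatic carbon, a 1.2-fold higher number from compound 1 to compound 2 (0.09 log units; within the scatter) and a 1.6-fold higher number from compound 1 to compound 3 (0.21 log units; within the scatter), were likewise within the scatter. On this evidence substitution at that nitrogen has not moved the read-out, and compound 4 is therefore expected to show at most a small step, a 1.5-fold higher number from compound 2 to compound 4 (0.17 log units; within the scatter), in this assay, not clearly beyond the scatter. The estimate for compound 4 is 100 nM, with a range from 45 nM to 230 nM.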

Compound 4, half-maximal inhibitory concentration: 600 nM
For compound 4 the middle estimate is 6.0-fold (0.78 log units) below the measured one, and the stated range ends below it.
By their numbers in this assay, from the lowest: compounds 1, 2 and 3 (each within the scatter of the next); then compound 4.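

In this assay the nitrogen on the aromatic ring proves not to be indifferent to what it carries: methylsulfonyl in place of hydrogen gives an 8.8-fold higher number from compound 2 to compound 4 (0.95 log units; beyond the scatter), whereas acetyl on the same nitrogen had stayed within the scatter. Methylsulfonyl in place of acetyl gives a 6.7-fold higher number from compound 3 to compound 4 (0.82 log units; beyond the scatter), and methanesulfonamido in place of methoxy on the aromatic carbon gives an 11-fold higher number from compound 1 to compound 4 (1.04 log units; beyond the scatter), so compound 4 stands apart from three compounds that had all remained within the scatter of one another. Nothing available here accounts for this separation between the methylsulfonyl group and the other groups at this position.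

The compounds shown leave open whether a longer chain on the sulfonyl group, as in ethylsulfonyl, or a trifluoromethylsulfonyl group on that nitrogen would give a number close to that of compound 4 or close to those of the other three. They also leave open what a methyl group in place of the hydrogen on the methanesulfonamido nitrogen would do, so the change to a sulfonyl group on this nitrogen rests on compound 4 alone.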